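The source may hold more compounds than are shown below. What is called first, only, known or untested is meant among the compounds shown, and "the series" means these compounds.

In a functional assay on HCT-116 cells (Homo sapiens) for antiproliferative activity, read by MTT assay, with a stated time of 72 h (a higher number here means a weaker inhibitor, a lower number a stronger inhibitor), compound 1 (`CC(C)CNC(=N)NC(=N)Nc1ccc(C(F)(F)F)cc1`) gives 3500 nM, while compound 2 (`CCN(CC)C(=N)NC(=N)Nc1ccc(F)c(F)c1`) gives 39400 nM, the higher of the two numbers and a gap beyond the usual scatter. Compound 3 (`N=C(NC(=N)NC1CCCC1)Nc1ccc(F)c(F)c1`) differs from compound 2 by cyclopentylamino in place of diethylamino on a carbon with a double bond to nitrogen, with cyclopentylamino in place of diethylamino on a carbon with a double bond to nitrogen. Among the compounds with values here, no measured pair isolates this change, so only a modest step towards a lower number is expected in this assay, little beyond the scatter. The estimated step is a 2.2-fold lower number from compound 2 to compound 3 (0.34 log units; beyond the scatter). For compound 3, the expected value is 18000 nM, with an estimated range of 6000 nM to 45000 nM.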

Compound 3, half-maximal inhibitory concentration: 16800 nM
Estimate against measurement, compound 3: 1.1-fold (0.03 log units) above; the measured number falls inside the stated range.
By their numbers in this assay, from the lowest: compound 1; then compound 3; then compound 2.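

In this assay, within the data shown here, the change to cyclopentylamino on a carbon with a double bond to nitrogen gives a 2.3-fold lower number from compound 2 to compound 3 (0.37 log units; beyond the scatter) as the first single-place comparison at this position, so the position does respond to this replacement, if modestly. The change adds a five-membered carbon ring and a hydrogen-bond donor together, and this pair cannot separate them. No measurement shown bears on the cause of the step. From the compounds shown here alone, whether cyclohexylamino or an unbranched butylamino chain would move the number further remains open. So does whether the step carries over to the core of compound 1.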